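Removal of One Hydroxy on the Aryl Urea Terminus

The source may report more compounds than this note shows. Statements on the series, on what has been measured and on what is new or still open speak of the compounds shown alone.

Compound 1 `COc1cc(C2CC(c3cc4ccccc4o3)=NN2C(=O)Cl)ccc1O` is the acid chloride of the shared core; in a functional assay on microsomes from liver (Rattus norvegicus, strain Wistar) for inhibition, with a stated time of 15 min (a higher number here means a weaker inhibitor, a lower number a stronger inhibitor), compound 1 gives 147000000 nM. Compound 2 `COc1cc(C2CC(c3cc4ccccc4o3)=NN2C(=O)Nc2ccccc2O)ccc1O` carries the (2-hydroxyphenyl)amino group on the carbonyl carbon and in this assay compound 2 gives 22000000 nM. Compound 3 `COc1cc(C2CC(c3cc4ccccc4o3)=NN2C(=O)Nc2ccc(O)c(O)c2)ccc1O` carries the (3,4-dihydroxyphenyl)amino group and in this assay compound 3 gives 11000000 nM, the lowest number of the three: compound 1 sits furthest from it (a 13-fold lower number from compound 1 to compound 3 (1.13 log units; beyond the scatter)), compound 2 nearest (a 2.0-fold lower number from compound 2 to compound 3 (0.30 log units; within the scatter)).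

Compound 4 `COc1cc(C2CC(c3cc4ccccc4o3)=NN2C(=O)Nc2ccc(O)cc2)ccc1O` differs from compound 3 in one place: hydrogen in place of hydroxy on an aromatic carbon. Among the compounds with values here, no measured step removes a hydroxy from this ring; the only step that changes its substitution pattern (a 2.0-fold lower number from compound 2 to compound 3 (0.30 log units; within the scatter)) stayed within the scatter, and both aryl urea compounds sit well below compound 1 (a 6.7-fold lower number from compound 1 to compound 2 (0.82 log units; beyond the scatter)). The replacement is therefore expected to give no step beyond the scatter, so that a 1.5-fold higher number from compound 3 to compound 4 (0.16 log units; within the scatter) is the estimated change. For compound 4 in this assay the estimate is 16000000 nM, with a range from 6000000 nM to 40000000 nM.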

Compound 4, half-maximal inhibitory concentration: 15000000 nM
Compound 4: middle estimate off by 1.1-fold (0.03 log units), on the high side, within the range that was stated.
By their numbers in this assay, from the lowest: compounds 3, 4 and 2 (each within the scatter of the next); then compound 1.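

Removing one hydroxy from the 3,4-dihydroxyphenyl group leaves the number in this assay within the scatter (a 1.4-fold higher number from compound 3 to compound 4 (0.13 log units; within the scatter)), so hydrogen and hydroxy at this place on the ring cannot be told apart. The single hydroxy of the 4-hydroxyphenyl group reads the same as that of the 2-hydroxyphenyl group (a 1.5-fold lower number from compound 2 to compound 4 (0.17 log units; within the scatter)), while replacing chloro with the (4-hydroxyphenyl)amino group still gives a step beyond the scatter (a 9.8-fold lower number from compound 1 to compound 4 (0.99 log units; beyond the scatter)), so the three aryl urea compounds form one group in this assay. Nothing available on these compounds accounts for these steps.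

On these data alone, whether this ring needs any hydroxy at all remains open. A plain phenyl group, or a methoxy group or a carboxylic acid in place of the remaining hydroxy, would address that question.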